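The source may report more compounds than this note shows. Statements on the series, on what has been measured and on what is new or still open speak of the compounds shown alone.

Of the compounds shown here, three that share one core have been measured in a functional assay on SH-SY5Y cells (Homo sapiens) for cytotoxicity, read by MTT assay, with stated times of 8 h, 30 min and 12 h, tested at 0.5 uM; on this read-out lower numbers stand for a weaker effect and higher numbers for a stronger effect at the one concentration tested. Compound 1 `COc1ccc(CNC(=N)[C@@H]2CCC(=O)N2Cc2ccc([N+](=O)[O-])cc2)cc1` gives 25.4%. Compound 2 `COc1ccc(CNC(=N)[C@@H]2CCC(=O)N2Cc2ccc(F)cc2)cc1` gives 36.7%. Compound 3 `COc1ccc(CN2C(=O)CC[C@H]2C(=N)NCc2ccccc2)cc1` gives 21%. Compound 3 thus sits at the low end of the three numbers: its distance to compound 1 lies within the scatter, while its distance to compound 2 lies beyond it.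

For the measured compounds named here, only one pair of measured compounds differs in a single place, and that step is a number 11.3 percentage points higher from compound 1 to compound 2 (beyond the scatter), a modest rise.

Compound 4 `COc1ccc(CNC(=N)[C@@H]2CCC(=O)N2Cc2ccc(OC)cc2)cc1` has not yet been measured in this assay. It differs from compound 3 by methoxy in place of hydrogen on an aromatic carbon. The methoxy enters on an aromatic carbon of a six-membered aromatic ring of carbon only, para to a large group. Going by the values given here, no measured step shows methoxy in place of hydrogen, so the step from compound 1 to compound 2 is only a loose guide: it shows that exchanging a nitro for a fluoro on that ring moves the number modestly, but a methoxy is a third, different group. The expected step is therefore small, a number 5 percentage points higher from compound 3 to compound 4 (within the scatter), and not beyond the scatter. Compound 4 is expected to give 26%, in a range from 13% to 40%.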

Compound 4, a percentage reported as activity, at one concentration (the size of the read-out at that concentration, not a potency): 24.8%
Beside the measured number, compound 4's estimate is 1.2 percentage points above it; the measured number falls inside the stated range.
By their numbers in this assay, from the lowest: compounds 3, 4 and 1 (each within the scatter of the next); then compound 2.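

Adding a methoxy to this aromatic carbon, turning phenyl into 4-methoxyphenyl, gives a number 3.8 percentage points higher from compound 3 to compound 4 (within the scatter) in this assay, so this change produces no clear shift from hydrogen. Comparing the groups at this place adds a second point: the change from nitro gives a number 0.6 percentage points lower from compound 1 to compound 4 (within the scatter), whereas the change from fluoro gives a number 11.9 percentage points lower from compound 2 to compound 4 (beyond the scatter), which leaves fluoro as the only one of these exchanges that separates clearly from methoxy, with methoxy and nitro remaining indistinguishable. Nothing available explains why fluoro stands apart from methoxy in this way.

The compounds shown leave open whether a chloro, an amine or a carboxylic acid at this place would fall with fluoro or with methoxy and nitro, and whether a longer chain such as ethoxy would differ from methoxy. They also leave open how these differences would look at other concentrations, since each number here comes from a single concentration and is not a potency.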